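The source may report more compounds than this note shows. Statements on the series, on what has been measured and on what is new or still open speak of the compounds shown alone.

Measured compounds:
- compound 1 `COc1ncnc2c1c(-c1ccccc1)cn2[C@@H]1O[C@H](CO)[C@@H](O)[C@H]1O` gives > 20000 nM (a limit)
- compound 2 `CNc1ncnc2c1c(-c1ccoc1)cn2[C@@H]1O[C@H](CO)[C@@H](O)[C@H]1O` gives > 15000 nM (a limit)
- compound 3 `Nc1nc(N)c2c(-c3ccco3)cn([C@@H]3O[C@H](CO)[C@@H](O)[C@H]3O)c2n1` gives > 20000 nM (a limit)

All three compounds were tested in a functional assay on HL-60 cells (Homo sapiens) for antiproliferative activity, read by XTT assay, with a stated time of 72 h (on this read-out lower numbers stand for stronger inhibition and higher numbers for weaker inhibition), and none of them yielded a number, only a limit of the assay. Compound 3 sits at the limit of > 20000 nM in this assay, at which 2 of the 3 values shown sit. Compound 2 sits at the other limit, (the limit of > 15000 nM in this assay, at which 1 of the 3 values shown sits). Compound 3 therefore has no measured number against which it can be placed.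

The next compound, compound 4 `Nc1nc(N)c2c(-c3ccsc3)cn([C@@H]3O[C@H](CO)[C@@H](O)[C@H]3O)c2n1`, keeps the shared core of compound 3 and changes one group, with thiophen-3-yl in place of furan-2-yl on an aromatic carbon. That carbon belongs to a five-membered aromatic ring with 1 nitrogen, part of a fused or bridged system of two rings. For the measured compounds named here, no measured pair shows what such an exchange does in this assay. The expectation rests on compound 3 at > 20000 nM, which is a limit. No change beyond the usual scatter is expected, and the assay may well report only a limit again. The expected size of the change is a number no higher from compound 3 to compound 4 (the limit leaves the size open). For compound 4 the estimated value is 20000 nM, with an expected range from 6000 nM to 40000 nM.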

Compound 4, half-maximal inhibitory concentration: > 20000 nM
Compound 4 was reported as a limit; the forecaster's own chance of this, stated with the estimate: 80%; the middle value sits exactly at the limit.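

Compound 3 and compound 4 are both reported only as limits, so the exchange of furan-2-yl for thiophen-3-yl cannot be read as a step of any size. The compounds shown leave open whether any group on the shared core gives a measured number rather than a limit in this assay.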